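Methoxy removal on two isomeric chromone cores

The source may hold more compounds than are shown below. What is called first, only, known or untested is meant among the compounds shown, and "the series" means these compounds.

Measured in a functional assay on HEp-2 cells (Homo sapiens) for antiproliferative activity, read by MTT assay, with a stated time of 72 h; a lower number here means a stronger inhibitor, a higher number a weaker inhibitor:
compound 1 `O=c1cc(CSC(=S)N2CCCCC2)oc2ccccc12` gives 12000 nM
compound 2 `COc1ccc2oc(CSC(=S)N3CCCCC3)cc(=O)c2c1` gives 1500 nM
compound 3 `COc1ccc2occ(CSC(=S)N3CCCCC3)c(=O)c2c1` gives 4300 nM

Compound 2 and compound 3 carry the same atoms joined differently; the difference between the two cores is not broken down here. Their numbers differ beyond the scatter, compound 2 giving the lower one.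

Within the core of compound 2, one change is measured: hydrogen in place of methoxy on an aromatic carbon. It gives an 8.0-fold higher number from compound 2 to compound 1 (0.90 log units; beyond the scatter).

Compound 4 `O=c1c(CSC(=S)N2CCCCC2)coc2ccccc12` is not yet measured. It stands to compound 3 as compound 1 stands to compound 2: hydrogen in place of methoxy on an aromatic carbon. The place lines are the same word for word, so this is the same change on the other core.

The expectation for compound 4 rests on a single measured pair, on a core that differs from that of compound 3 in a way not counted here. A weakening step is expected, of roughly the size seen with an 8.0-fold higher number from compound 2 to compound 1 (0.90 log units; beyond the scatter), and is estimated at a 5.8-fold higher number from compound 3 to compound 4 (0.76 log units; beyond the scatter). Because compound 3 gives 4300 nM, compound 4 is expected near 25000 nM, within 8000 nM to 80000 nM.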

Compound 4, half-maximal inhibitory concentration: 390 nM
For compound 4 the middle estimate is 64-fold (1.81 log units) above the measured one, and the stated range ends above it.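

In this assay, hydrogen in place of methoxy on an aromatic carbon gives an 11-fold lower number from compound 3 to compound 4 (1.04 log units; beyond the scatter), so on this core the change goes with a lower number, not the higher one seen on the other core. The change therefore does not carry from one core to the other in this series, in either direction or size: the same change on two cores in this assay, an 8.0-fold higher number (0.90 log units; beyond the scatter) from compound 2 to compound 1 and an 11-fold lower number (1.04 log units; beyond the scatter) from compound 3 to compound 4, 88-fold (1.95 log units) apart, beyond the scatter of two such steps. For the compounds shown here, this rests on only two pairs, so it shows that the outcome of this change depends on the core, but it does not show why, and it establishes no property of the methoxy group or of either core.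

On these data alone, it remains open whether other groups on the same aromatic carbon, such as hydroxyl, fluorine or a longer ether chain, would also separate the two cores. As far as these compounds go, it also remains open whether the split between the cores would persist if the piperidine-bearing side chain were replaced by one ending in an amine or a carboxylic acid.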